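From furan-2-yl to pyridin-3-yl at the assay limit

A few compounds are considered here, and "the series" means these few. Any claim that something is new, unique, unknown or untested is made for them only; others in the source may bear on it.

Compound 1 `Oc1ccccc1-c1cc(-c2ccco2)cc(-c2ccccc2O)n1` gives > 50000 nM (a limit)
Compound 2 `Oc1cccc(-c2cc(-c3ccco3)cc(-c3ccccc3O)n2)c1` gives > 50000 nM (a limit)
Compound 3 `Oc1ccc(-c2cc(-c3ccco3)cc(-c3cccc(O)c3)n2)cc1` gives 840 nM (a number)

All three were tested in a functional assay on HCT-15 cells (Homo sapiens) for cytotoxicity, read by CCK-8 assay; on this read-out lower numbers stand for stronger inhibition and higher numbers for weaker inhibition. Compound 2 stands at > 50000 nM, which is a limit and not a number. The same limit holds for most of the set: the limit of > 50000 nM in this assay, at which 2 of the 3 values shown sit. Compound 4 `Oc1cccc(-c2cc(-c3cccnc3)cc(-c3ccccc3O)n2)c1` keeps the 2-hydroxyphenyl and 3-hydroxyphenyl groups of compound 2 and carries pyridin-3-yl in place of furan-2-yl on an aromatic carbon. Going by the values given here, no measured step changes the furan-2-yl group, so the evidence is indirect. The first step, a step that the two limits leave unreadable from compound 1 to compound 2, tells nothing. The second, an at least 59-fold lower number from compound 2 to compound 3 (1.77 log units; beyond the scatter), is large, but it comes from changing a hydroxyphenyl group, and compound 4 keeps those groups as in compound 2. A large drop in this assay is therefore not expected, and any readable change would be towards a lower number. The estimate means an expected at least 1.6-fold lower number from compound 2 to compound 4 (0.22 log units; that floor lies within the scatter). For compound 4 the expected value is 30000 nM, with an estimated range from 6000 nM to 50000 nM.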

Compound 4, half-maximal inhibitory concentration: 8280 nM
For compound 4 the middle estimate is 3.6-fold (0.56 log units) above the measured one; measured number inside the range.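

In this assay, the group opposite the ring nitrogen proves to count: with both hydroxyphenyl groups unchanged, pyridin-3-yl in place of furan-2-yl gives an at least 6.0-fold lower number from compound 2 to compound 4 (0.78 log units; beyond the scatter). Going by these compounds alone, the earlier readable step came from moving a hydroxyl-bearing group, so this is the first sign that this other position can also shift the number, and compound 4 shows that a 2-hydroxyphenyl and 3-hydroxyphenyl pair can give a real number rather than a limit. The value of compound 2 is a limit and not a number, so this step has a floor only: the limit of > 50000 nM in this assay, at which 2 of the 4 values shown sit.

It remains open whether the ring nitrogen of pyridin-3-yl matters, as a plain phenyl or a pyridin-4-yl at this position is not among the compounds shown. Also open, going by these compounds, is how pyridin-3-yl would act on the hydroxyphenyl groups of compound 3.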